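The compounds below may be only part of what the source reports. "The series", "measured", "known", "first", "only" and "open" are said of these compounds alone.

Compound 1 `O=CN(O)C(CCc1ncccn1)CS(=O)(=O)N1CCN(c2ccc(Cl)cn2)CC1` — < 10000 nM
Compound 2 `CCCc1c(OCCCOc2ccc3c(=O)cc(CCC(=O)O)oc3c2CCC)ccc(C(C)=O)c1O` — < 10000 nM
Compound 3 `C[C@H](Oc1ccc(C(F)(F)F)cc1-c1ccc(S(C)(=O)=O)c(C(F)(F)F)c1)C(=O)O` — 35800 nM

These three compounds were tested in an ADME assay for inhibition of Bile salt export pump (Homo sapiens), read by scintillation counting, with a stated time of 5 min; on this read-out higher numbers stand for weaker inhibition and lower numbers for stronger inhibition. The value for compound 1 is a limit of the assay, not a number. The value for compound 2 is a limit as well. Only compound 3 has a numeric result, and compound 3 gives 35800 nM. Where compound 1 stands among these results can therefore be said only loosely: it sits at the limit of < 10000 nM in this assay, at which 2 of the 3 values shown sit, so its true value may lie anywhere beneath that line, and no ordering between compound 1 and compound 2 can be read from two limits.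

Compound 4 `O=CN(O)C(CCc1cccnc1)CS(=O)(=O)N1CCN(c2ccc(Cl)cn2)CC1` has not yet been measured. Compared with compound 1, the change is pyridin-3-yl in place of pyrimidin-2-yl on a saturated chain carbon, three bonds along the chain from an amide-type nitrogen. For the measured compounds named here, no pair of measured compounds in this set carries this change, so the set itself gives no measure of its effect. The expected step in this assay is a step that the limit leaves unreadable from compound 1 to compound 4, that is, nothing beyond the usual scatter, an expectation resting only on compound 1 sitting at the limit of < 10000 nM in this assay, at which 2 of the 3 values shown sit. Compound 4 is expected to give about 5000 nM, within 1500 nM to 10000 nM, and most likely the assay will again report only a limit.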

Compound 4, half-maximal inhibitory concentration: < 10000 nM
Compound 4: only a limit was reported (the forecaster's own chance of this, stated with the estimate: 70%); the middle value does not contradict the limit.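

Compound 1 and compound 4 are both reported in this assay only as limits of the assay, not as numbers, so no step between them can be read: the limit of < 10000 nM in this assay, at which 3 of the 4 values shown sit.

The compounds shown leave open whether pyridin-3-yl in place of pyrimidin-2-yl shifts the true value at all, and if so, in which direction and how far.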